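Nitro in Place of Chloro on the Benzyl Ring

A few compounds are considered here, and "the series" means these few. Any claim that something is new, unique, unknown or untested is made for them only; others in the source may bear on it.

Compound 2 `O=C(/C=C/c1ccc(OCc2nc(C3CCN(Cc4ccccc4Cl)CC3)no2)cc1)NO` stands at 59% in an assay on isolated protein for inhibition of protein deacetylase HDAC6 (Homo sapiens), read by fluorescence, with a stated time of 1 h, tested at 100 nM; on this read-out higher numbers stand for more inhibition at the one concentration tested (going by the name of the read-out) and lower numbers for less inhibition. Its nearest neighbour, compound 1 `CCCN1CCC(c2noc(COc3ccc(/C=C/C(=O)NO)cc3)n2)CC1`, gives 69%, and the step of a number 10 percentage points lower from compound 1 to compound 2 (within the scatter) sits within the scatter. Compound 3 `O=C(/C=C/c1ccc(OCc2nc(C3CCN(Cc4ccccc4[N+](=O)[O-])CC3)no2)cc1)NO` differs from compound 2 by nitro in place of chloro on an aromatic carbon. Going by the values given here, no measured step alters a group on this aromatic ring, and the single known step of a number 10 percentage points lower from compound 1 to compound 2 (within the scatter) stayed within the scatter, so no shift beyond the scatter is expected. Compound 3 is estimated to give about 55%, between 35% and 75%. The expected step is a number 4 percentage points lower from compound 2 to compound 3 (within the scatter), within the scatter.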

Compound 3, a percentage reported as inhibition, at one concentration (the size of the read-out at that concentration, not a potency): 63%
Beside the measured number, compound 3's estimate is 8 percentage points below it, within the range that was stated.
By their numbers in this assay, from the lowest: compounds 2, 3 and 1 (each within the scatter of the next).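

In this assay, nitro in place of chloro on this aromatic carbon gives a number 4 percentage points higher from compound 2 to compound 3 (within the scatter), the first step shown that alters a group on this ring, and neither group stands apart from the other. 2-Nitrophenyl in place of ethyl gives a number 6 percentage points lower from compound 1 to compound 3 (within the scatter), so this change of the chain end also stays within the scatter. Nothing measured here bears on why these numbers lie so close. Going by these compounds, it remains open whether an amine or a carboxylic acid on the same aromatic carbon would also stay within the scatter. The compounds shown also leave open what chloro or nitro would give on another carbon of this ring.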